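The source may hold more compounds than are shown below. What is called first, only, known or untested is meant among the compounds shown, and "the series" means these compounds.

Among the compounds with values here, in a functional assay on THP-1 cells (Homo sapiens) for inhibition, read by ELISA, with stated times of 2 h and 48 h (on this read-out higher numbers stand for weaker inhibition and lower numbers for stronger inhibition), compound 1 `[O-]/[N+](=C\c1cn(-c2ccccc2)nn1)c1ccccc1` gives 8800 nM, the only actual number so far. Compound 2 `[O-]/[N+](=C\c1cn(-c2ccc(F)cc2)nn1)c1ccccc1` reads > 20000 nM, which is a limit. Compound 3 `[O-]/[N+](=C\c1cn(-c2ccc(Cl)cc2)nn1)c1ccccc1` reads > 20000 nM, again a limit. Compound 4 `CC(C)(C)/[N+]([O-])=C/c1cn(-c2ccccc2)nn1` carries tert-butyl in place of phenyl on a double-bonded nitrogen. The two measured steps, an at least 2.2-fold higher number from compound 1 to compound 2 (0.35 log units; beyond the scatter) and an at least 2.2-fold higher number from compound 1 to compound 3 (0.35 log units; beyond the scatter), are both beyond the scatter, but each replaces hydrogen on an aromatic carbon, so neither touches this place and they bear on it only loosely. With compound 1 at 8800 nM as the sole anchor, no clear shift is expected in this assay. The estimated step is a 1.4-fold higher number from compound 1 to compound 4 (0.13 log units; within the scatter), not beyond the scatter. For compound 4 the expected value is 12000 nM, with an estimated range of 4000 nM to 30000 nM.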

Compound 4, half-maximal inhibitory concentration: > 20000 nM
Compound 4 gave a limit, no number; the forecaster's own chance of this, stated with the estimate: 40%; at least 1.6-fold (0.22 log units) between middle value and limit.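

In this assay, within the data shown here, the swap on the double-bonded nitrogen gives an at least 2.2-fold higher number from compound 1 to compound 4 (0.35 log units; beyond the scatter) as the first readable step at this place, since the earlier steps touched only hydrogen on an aromatic carbon. Within this pair, tert-butyl does not retain the inhibition seen with phenyl, so this position responds to the change. Compound 4 reads as a limit, so the full size of the step stays unknown, and the series has a single actual number: the limit of > 20000 nM in this assay, at which 3 of the 4 values shown sit.

Open, going by these compounds, is whether a methyl group or a longer chain on this nitrogen would match compound 1. Also open, on these data alone, is how an amine or a carboxylic acid on the phenyl would read.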